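The compounds below may be only part of what the source reports. "The series", "measured", "known", "first", "only" and "open" are said of these compounds alone.

compound 1 `COCCC(=O)Nc1cnc(NCc2c(F)ccc3c2CCO3)n2cnnc12`: 980000 nM
compound 2 `Cc1ncc(-c2cnc(NCc3c(F)ccc4c3CCO4)c3cn[nH]c(=O)c23)n1C`: 15000 nM
compound 3 `CN(c1ccn(C)n1)c1cnc(NCc2c(F)ccc3c2CCO3)n2cnnc12`: 130000 nM

All three values come from a physicochemical assay for solubility, read by LC-MS, in phosphate buffer, with a stated time of 24 h, at pH 7.4; a higher number here means a more soluble compound, a lower number a less soluble compound. Compound 3, at 130000 nM, has the second highest of the three numbers, with compound 1 higher at 980000 nM and compound 2 lower at 15000 nM.

The next compound is compound 4 `O=C1CCCN1c1cnc(NCc2c(F)ccc3c2CCO3)n2cnnc12`, which has 2-oxopyrrolidin-1-yl in place of methyl(1-methyl-1H-pyrazol-3-yl)amino on an aromatic carbon.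

Within the data shown here, one measured step bears on this change: a 7.5-fold lower number from compound 1 to compound 3 (0.88 log units; beyond the scatter), a modest step beyond the scatter. That step brought in the same methyl(1-methyl-1H-pyrazol-3-yl)amino group that now leaves. Compound 2 differs from the others in more than one place, so it offers no direct comparison. The group entering compound 4 carries a carbonyl, as does the ((2-methoxyethyl)carbonyl)amino group of compound 1, but the two groups are not the same and compound 4 has no amide hydrogen. Only part of that earlier drop is therefore expected to be recovered, so the number should rise rather than fall. The expected change is a 3.1-fold higher number from compound 3 to compound 4 (0.49 log units; beyond the scatter). For compound 4 the estimated value in this assay is 400000 nM, with an expected range from 130000 nM to 1000000 nM.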

Compound 4, solubility: 640000 nM
Compound 4: middle estimate off by 1.6-fold (0.20 log units), on the low side, within the range that was stated.
By their numbers in this assay, from the lowest: compound 2; then compound 3; then compounds 4 and 1 (each within the scatter of the next).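

In this assay, among these compounds, the only earlier step at this aromatic carbon was a 7.5-fold lower number from compound 1 to compound 3 (0.88 log units; beyond the scatter) and the new one runs the other way: 2-oxopyrrolidin-1-yl in place of methyl(1-methyl-1H-pyrazol-3-yl)amino gives a 4.9-fold higher number from compound 3 to compound 4 (0.69 log units; beyond the scatter) so the number can be raised again by changing this one group while the shared core stays as it is. Set against the ((2-methoxyethyl)carbonyl)amino group, the same ring gives a 1.5-fold lower number from compound 1 to compound 4 (0.19 log units; within the scatter) which means that a group without the amide hydrogen can stand at this position with a number that cannot be told apart from that of compound 1. The compounds shown carry no separate measurement that explains why the numbers move in this way.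

Still open, going by these compounds, is how a six-membered lactam, an open-chain amide, an amine such as morpholine or a carboxylic acid would read at this same aromatic carbon. Also open, on these data alone, is whether 2-oxopyrrolidin-1-yl would bring a similar step on the core of compound 2, which differs from the other compounds in more than one place.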